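The source may hold more compounds than are shown below. What is called first, only, known or untested is meant among the compounds shown, and "the series" means these compounds.

Measured so far:
- compound 1, `Cc1cccc(/C=N/Nc2ncc3c(n2)n(C2CCCC2)c(=O)c(=O)n3C)c1`: 53600 nM
- compound 2, `Cn1c(=O)c(=O)n(C2CCCC2)c2nc(N/N=C/c3ccco3)ncc21`: 72200 nM
- compound 3, `Cc1cc(C)c(/C=N/Nc2ncc3c(n2)n(C2CCCC2)c(=O)c(=O)n3C)c(C)c1`: 13900 nM

In a functional assay on PC-3 cells (Homo sapiens) for antiproliferative activity, read by MTT assay (on this read-out higher numbers stand for weaker inhibition and lower numbers for stronger inhibition), compound 3 gives the lowest of the three numbers, and its steps to compound 1 and compound 2 both lie beyond the scatter. Compound 4, `Cn1c(=O)c(=O)n(C2CCCC2)c2nc(N/N=C/c3cccc(O)c3)ncc21`, differs from compound 3 in one place: 3-hydroxyphenyl in place of 2,4,6-trimethylphenyl on a carbon with a double bond to nitrogen. The step that bears on this is a 3.9-fold lower number from compound 1 to compound 3 (0.59 log units; beyond the scatter), where the same 2,4,6-trimethylphenyl was introduced; the single-substituted ring in compound 4 resembles compound 1 more closely. A similar-sized step back up is therefore expected, a 3.2-fold higher number from compound 3 to compound 4 (0.51 log units; beyond the scatter). Compound 4 is expected at about 45000 nM in this assay, within roughly 18000 nM to 110000 nM.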

Compound 4, half-maximal inhibitory concentration: 36300 nM
Compound 4: the middle estimate sits 1.2-fold (0.09 log units) above what was measured; measured number inside the range.
By their numbers in this assay, from the lowest: compound 3; then compounds 4, 1 and 2 (each within the scatter of the next).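

Measured in this assay, hydroxy in place of methyl on an aromatic carbon gives a 1.5-fold lower number from compound 1 to compound 4 (0.17 log units; within the scatter) and 3-hydroxyphenyl in place of furan-2-yl gives a 2.0-fold lower number from compound 2 to compound 4 (0.30 log units; within the scatter) so a ring carrying a hydrogen-bond donor and acceptor does not separate from these two. Among these compounds, only 2,4,6-trimethylphenyl stands apart, with a 2.6-fold higher number from compound 3 to compound 4 (0.42 log units; beyond the scatter) as the one new step beyond the scatter. Nothing measured here gives a reason for that gap.

Still open, going by these compounds, is whether an amine or a carboxylic acid on the same ring would also leave the number unmoved. Open too, on these data alone, is whether a phenyl ring with two methyl groups would keep the lower number of compound 3.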